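The compounds below may be only part of what the source reports. "The series", "measured", "known", "first", "only" and "open" are said of these compounds alone.

Compound 1 `CCCCCCCCc1ccc(OCC(=O)Cn2nnc(C(=O)OC)n2)cc1`: in an ADME assay on S9 fraction from liver (Rattus norvegicus) for metabolic stability, read by LC-MS, using NADPH, with a stated time of 30 min (a higher number here means that more of the compound is left, a lower number that less of the compound is left), it reports < 5%, a limit.
Compound 2 `CCCCCCCCc1ccc(OCC(=O)Cn2nnc(-c3cccc(C(=O)O)c3)n2)cc1`: < 5%, a limit.
Compound 3 `CCCCCCCCc1ccc(OCC(=O)Cn2nnnc2-c2ccc(S(=O)(=O)N(C)C)cc2)cc1`: 40%.

Compound 3 is the only one of the three with an actual number in this assay; the other two sit at the limit of < 5% in this assay, at which 2 of the 3 values shown sit. The step from compound 1 to compound 2 is a step that the two limits leave unreadable from compound 1 to compound 2, so its size stays hidden. Compound 4 `CCCCCCCCc1ccc(OCC(=O)Cn2nnnc2-c2cccc(C(=O)O)c2)cc1` differs from compound 3 by 3-carboxyphenyl in place of 4-(dimethylsulfamoyl)phenyl on an aromatic carbon. For the measured compounds named here, no measured step covers this exact change, but compound 2, which carries the same 3-carboxyphenyl, reports only the limit < 5%, and that points toward a fall. Compound 4 is therefore estimated at 15%, within 0% to 35%. The expected step is then a number 25 percentage points lower from compound 3 to compound 4 (beyond the scatter).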

Compound 4, percent of the compound remaining: < 5%
Compound 4: a limit, no number (the forecaster's own chance of this, stated with the estimate: 40%); at least 10 percentage points between middle value and limit.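

For the compounds shown here, at this position, on the aromatic carbon between two ring nitrogen atoms, 3-carboxyphenyl in place of 4-(dimethylsulfamoyl)phenyl gives the first readable change in this assay: a number at least 35 percentage points lower from compound 3 to compound 4 (beyond the scatter). The earlier compounds shown here offered no such reading, and the value of compound 4, < 5%, is a limit, so the full size of the drop stays hidden. Compound 3 alone keeps a number, while the others share one floor: the limit of < 5% in this assay, at which 3 of the 4 values shown sit.

The compounds shown leave open how an unsubstituted phenyl or a phenyl carrying an amine would behave at this place. The change therefore cannot yet be divided between losing the dimethylsulfamoyl group and gaining the carboxylic acid.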